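Series notes: heteroaromatic group in place of trifluorophenyl

A few compounds are considered here, and "the series" means these few. Any claim that something is new, unique, unknown or untested is made for them only; others in the source may bear on it.

Measured so far in an assay on Sf9 cells for inhibition of prolyl hydroxylase EGLN2 (Homo sapiens), read by TR-FRET, with stated times of 30 min and 2 h; a lower number here means a stronger inhibitor, a higher number a weaker inhibitor:
compound 1 `O=C(O)CNC(=O)c1c(O)c2c(n(Cc3ccc(Cl)cc3)c1=O)COC2` gives 2.1 nM
compound 2 `O=C(O)CNC(=O)c1c(O)c2c(n(Cc3cc(F)c(F)cc3F)c1=O)COC2` gives 3.1 nM
compound 3 `O=C(O)CNC(=O)c1c(O)c2c(n(Cc3cnc(C(F)(F)F)nc3)c1=O)COC2` gives 11 nM

Compound 2 holds the second highest of the three numbers. Its nearest neighbour is compound 1, whose number lies within the scatter of it; its furthest is compound 3, whose number lies beyond the scatter above it. Within the data shown here, only one step between single-point changes is measured: a 1.5-fold higher number from compound 1 to compound 2 (0.17 log units; within the scatter), a change that stays within the scatter.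

Compound 4 `O=C(O)CNC(=O)c1c(O)c2c(n(Cc3nc4ccccc4o3)c1=O)COC2` differs from compound 2 by 1,3-benzoxazol-2-yl in place of 2,4,5-trifluorophenyl on a saturated chain carbon bound to an aromatic nitrogen. Among the measured compounds shown here, no measured step exchanges a carbon-only aromatic ring for one with hetero atoms at this position, so the one measured step bears only loosely on it, as it swaps 4-chlorophenyl for 2,4,5-trifluorophenyl. For the measured compounds named here, compound 2 and compound 3 show only that compound 3, which carries a heteroaromatic ring at the same place, has the higher number.

On that basis a moderate rise is expected, a 2.3-fold higher number from compound 2 to compound 4 (0.35 log units; beyond the scatter), which may or may not clear the scatter. For compound 4 the estimated value in this assay is 7 nM, with a range from 2.5 nM to 22 nM.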

Compound 4, half-maximal inhibitory concentration: 5 nM
Compound 4: middle estimate off by 1.4-fold (0.15 log units), on the high side, within the range that was stated.
By their numbers in this assay, from the lowest: compounds 1, 2 and 4 (each within the scatter of the next, the first and the last beyond it); then compound 3.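

In this assay, 1,3-benzoxazol-2-yl brings a five-membered aromatic ring with hetero atoms and hydrogen-bond acceptors onto the saturated chain carbon bound to an aromatic nitrogen, yet the exchange gives a 1.6-fold higher number from compound 2 to compound 4 (0.21 log units; within the scatter), so this heteroaromatic group stays level with 2,4,5-trifluorophenyl within the scatter. The same group separates only from 4-chlorophenyl, with a 2.4-fold higher number from compound 1 to compound 4 (0.38 log units; beyond the scatter), and compound 3, the other heteroaromatic example, stands at 11 nM against compound 4 at 5 nM, so hetero atoms in the group at this place do not by themselves fix the number at the level of compound 3. Nothing available explains why 1,3-benzoxazol-2-yl reads as it does here.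

Still open, going by these compounds, is how much of the result rests on the carbon-only six-membered ring of 1,3-benzoxazol-2-yl, which a plain oxazol-2-yl group would test. Also open, on these data alone, is whether the ring oxygen counts, which 1,3-benzothiazol-2-yl, with sulfur in its place, or 1-methylbenzimidazol-2-yl, with nitrogen, would show on the same chain carbon.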